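Methyl on the pyrazole nitrogen: expected rat plasma exposure

The source may hold more compounds than are shown below. What is called first, only, known or untested is meant among the compounds shown, and "the series" means these compounds.

Compound 1 `CC(=O)Nc1cc(-c2c(Nc3cc[nH]n3)nc3ccccn23)nc(C)n1` gives 209 ng.h/mL in an ADME assay on the whole organism (plasma) for pharmacokinetics, with Rattus norvegicus as the target, at a dose of 0.5 mg/kg by the intravenous route; on this read-out higher numbers stand for higher exposure at the dose given and lower numbers for lower exposure. Compound 2 `CC(=O)Nc1cc(-c2c(Nc3cc[nH]n3)nc3cccnn23)nc(C)n1` gives 210 ng.h/mL in this assay.

These two compounds share a core and differ only in the fused ring of that core. Their two numbers lie within the usual scatter of each other, so neither can be set above the other: compound 1 and compound 2 simply give the same exposure as far as this measurement can tell.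

Compound 3 `CC(=O)Nc1cc(-c2c(Nc3ccn(C)n3)nc3ccccn23)nc(C)n1` differs from compound 1 by methyl in place of hydrogen on an aromatic nitrogen. Among the measured compounds shown here, no measured pair shows this change, so its effect on exposure is not known from the data at hand. With nothing pointing in either direction, the step from compound 1 to compound 3 is estimated as a 1.1-fold higher number from compound 1 to compound 3 (0.06 log units; within the scatter), meaning no change beyond the usual scatter is expected. Compound 3 is therefore expected to give 240 ng.h/mL, within a range from 90 ng.h/mL to 700 ng.h/mL.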

Compound 3, area under the concentration-time curve: 834 ng.h/mL
Compound 3: the middle estimate sits 3.5-fold (0.54 log units) below what was measured; the measured number lies above the stated range.
By their numbers in this assay, from the lowest: compounds 1 and 2 (each within the scatter of the next); then compound 3.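

In this assay, the nitrogen of the pyrazole proves to be a place where a very small change counts: replacing hydrogen with methyl, a single carbon, gives a 4.0-fold higher number from compound 1 to compound 3 (0.60 log units; beyond the scatter). The change in the fused ring of the core, seen between compound 1 and compound 2, left the two numbers within the scatter of each other, so this is the first change among these compounds to move exposure beyond it. No available measurement explains why the methyl has this effect.

On these data alone, this rests on one pair, so it remains open whether methyl in place of hydrogen would give a similar step on the core of compound 2. As far as these compounds go, it is also open whether an ethyl group or a longer chain ending in an amine on this same nitrogen would raise exposure further, match methyl or lose the gain.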